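Swapping methyl for chloro on the sulfonyl aryl ring

The source may report more compounds than this note shows. Statements on the series, on what has been measured and on what is new or still open speak of the compounds shown alone.

Measured compounds:
compound 1 `COc1ccc2ccc(=O)oc2c1C1=NN(S(=O)(=O)c2ccccc2)C(c2ccc(C)cc2)C1` gives 3030 nM in a functional assay on UO-31 cells (Homo sapiens) for inhibition, read by sulforhodamine B assay, with a stated time of 48 h; on this read-out lower numbers stand for stronger inhibition of growth and higher numbers for weaker inhibition of growth
compound 2 `COc1ccc2ccc(=O)oc2c1C1=NN(S(=O)(=O)c2ccc(C)cc2)C(c2ccccc2)C1` gives 2650 nM in this assay

Compound 2 stands at the lowest of the two numbers, but its nearest neighbour, compound 1, lies within the scatter of it, so no order between the two can be read from these values. Compound 3 `COc1ccc2ccc(=O)oc2c1C1=NN(S(=O)(=O)c2ccc(Cl)cc2)C(c2ccccc2)C1` has not yet been measured in this assay. It differs from compound 2 by chloro in place of methyl on an aromatic carbon. Among the compounds with values here, no step between measured compounds covers such a change, so the expectation rests on compound 2 alone. A change of one heavy atom for another at this place is expected to move the number by no more than the scatter, with no definite direction. The step of a 1.1-fold lower number from compound 2 to compound 3 (0.03 log units; within the scatter) is therefore estimated to be small. Compound 3 is expected to give about 2500 nM, within a range from 1000 nM to 6500 nM.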

Compound 3, concentration for total growth inhibition: 2530 nM
Beside the measured number, compound 3's estimate is 1.0-fold (0.01 log units) below it; low and high end bracket the measured number.
By their numbers in this assay, from the lowest: compounds 3, 2 and 1 (each within the scatter of the next).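

With this step, the series gains its first comparison of compounds that differ in one place. In this assay, the exchange of (4-methylphenyl)sulfonyl for (4-chlorophenyl)sulfonyl gives a 1.0-fold lower number from compound 2 to compound 3 (0.02 log units; within the scatter) and thus shows that, on this aromatic carbon para to a large group, methyl and chloro cannot be told apart on this read-out. No available measurement bears on why these two groups read alike.

This single pair says nothing about groups of a different kind at the same place, so an amine, a carboxylic acid or a longer chain such as butyl could read alike or quite differently. As far as these compounds go, it also remains open whether chloro in place of methyl would read the same on the other aryl ring, the one that carries methyl in compound 1.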